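The source may report more compounds than this note shows. Statements on the series, on what has been measured and on what is new or still open speak of the compounds shown alone.

Compound 1 `COc1ccc(-c2ccc(OC)c3oc(C(=O)Nc4ccc(Cn5ccnc5)cc4)cc23)cc1` in a functional assay on the whole organism for inhibition, with Mus musculus as the target, at a dose of 10 mg/kg by the oral route (a lower number here means less inhibition, a higher number more inhibition at the dose given (going by the name of the read-out)), gives 54%. Compound 2 `COC(=O)c1ccc(OC)c2oc(C(=O)Nc3ccc(OC)cc3)cc12` stands at "not determined" (no result reported) in this assay, so no number is available for it there. Compound 3 `COC(=O)c1ccc(OC)c2oc(C(=O)Nc3ccc(Cn4ccnc4)cc3)cc12` differs from compound 2 by (1H-imidazol-1-yl)methyl in place of methoxy on an aromatic carbon. With no measured step of this kind in the series, the size of the change in this assay from compound 2 to compound 3 cannot be read from a number, and a shift beyond the scatter in either direction remains possible. The (1H-imidazol-1-yl)methyl group that enters is also carried by compound 1, which gives 54%. On that basis compound 3 is expected to give about 40% in this assay, within 15% to 65%.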

Compound 3, a percentage reported as inhibition, in the whole organism at one dose (the size of the read-out at that dose, not a potency): 0%
Compound 3: the middle estimate sits 40 percentage points above what was measured, and the stated range ends above it.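

With the (1H-imidazol-1-yl)methyl group held fixed, the group on the aromatic carbon of the shared core matters in this assay, where methoxycarbonyl in place of 4-methoxyphenyl goes with a number 54 percentage points lower from compound 1 to compound 3 (beyond the scatter) here. In this pair, the (1H-imidazol-1-yl)methyl group alone does not secure inhibition at the dose given. Nothing measured here accounts for the loss.

The step from compound 2 to compound 3 cannot be read, as compound 2 has no number. Open, as far as these compounds go, is whether a carboxylic acid, an amine or an unsubstituted phenyl ring in place of methoxycarbonyl would restore inhibition.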